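Bromo for chloro at the edge of the limit

A few compounds are considered here, and "the series" means these few. Any claim that something is new, unique, unknown or untested is made for them only; others in the source may bear on it.

In an ADME assay on HaCaT cells (Homo sapiens) for cytotoxicity, read by MTT assay, with a stated time of 48 h (on this read-out higher numbers stand for weaker inhibition and lower numbers for stronger inhibition), compound 3 `Clc1ccc(-c2nn(-c3ccccc3)cc2-c2nc3cc(Cl)ccc3[nH]2)cc1` gives > 50000 nM, which is a limit and not a number. Compound 2 `Clc1ccc(-c2nn(-c3ccccc3)cc2-c2nc3ccccc3[nH]2)cc1` gives > 50000 nM, which is also a limit. Together these two form (the limit of > 50000 nM in this assay, at which 2 of the 3 values shown sit), so compound 3 has no exact place on the scale.

The next compound, compound 4 `Clc1ccc(-c2nn(-c3ccccc3)cc2-c2nc3cc(Br)ccc3[nH]2)cc1`, comes from compound 3 through one change: bromo in place of chloro on an aromatic carbon.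

Among the compounds with values here, the one measured step nearby is a step that the two limits leave unreadable from compound 2 to compound 3, and it offers no size to carry forward. Within the data shown here, the only number comes from compound 1 `Fc1ccc(-c2nn(-c3ccccc3)cc2-c2nc3cc(Br)ccc3[nH]2)cc1`, which also carries a bromo group and gives 21800 nM. That value suggests compound 4 could give a number in this assay, although another limit remains about as likely. A modest move towards stronger inhibition is therefore expected, with its size poorly defined.

The expected change is an at least 1.2-fold lower number from compound 3 to compound 4 (0.09 log units; that floor lies within the scatter). Compound 4 is estimated at 40000 nM, with an expected range from 18000 nM to 70000 nM.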

Compound 4, half-maximal inhibitory concentration: > 50000 nM
Compound 4 gave a limit, no number; the forecaster's own chance of this, stated with the estimate: 55%; at least 1.2-fold (0.09 log units) between middle value and limit.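

In this assay compound 4 gives > 50000 nM, which is a limit and not a number. Within the data shown here, with bromo held in place on the fused ring system, the one readable comparison is an at least 2.2-fold higher number from compound 1 to compound 4 (0.36 log units; beyond the scatter), which goes with chloro in place of fluoro on an aromatic carbon of the other part of the molecule, so a change away from this position separates a number from a limit. The steps among compound 2, compound 3 and compound 4 cannot be read, because all three sit at the same ceiling: the limit of > 50000 nM in this assay, at which 3 of the 4 values shown sit.

As far as these compounds go, how far compound 2, compound 3 and compound 4 lie beyond that limit stays open, so hydrogen, chloro and bromo at this position cannot be put in order. From the compounds shown here alone, it is also open whether an amine or a carboxylic acid here would give a number in this assay.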